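This account rests on a few compounds, and the source may have more. Where it says the series, first, only, none or still open, it means among the compounds named here.

Measured compounds and their values:

compound 1, `N/C(=N\NC(=S)N1CCSCC1)c1ccccn1`: 37.2%
compound 2, `Cc1ccnc(/C(N)=N/NC(=S)N2CCCCCC2)c1`: 36.1%
compound 3, `N/C(=N\NC(=S)N1CCOCC1)c1ccc(F)cn1`: 47%

All three numbers come from a functional assay on A-431 cells (Homo sapiens) for cytotoxicity, read by MTT assay, with a stated time of 72 h, tested at 3 uM; on this read-out lower numbers stand for less inhibition of growth and higher numbers for more inhibition of growth at the one concentration tested. Compound 3 gives the highest of the three numbers. Its nearest neighbour is compound 1, whose number lies within the usual scatter of compound 3, so no order between compound 3 and compound 1 can be read from these two values. Compound 2 lies furthest from compound 3, beyond the scatter, so compound 3 sits above compound 2 on this read-out.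

Compound 4, `N/C(=N\NC(=S)N1CCOCC1)c1ccccn1`, has not yet been measured in this assay. It differs from compound 3 in one place: hydrogen in place of fluoro on an aromatic carbon. The change is small in count, a hydrogen in place of fluoro on an aromatic carbon, and the rest of the molecule is unchanged.

Within the data shown here, no pair of measured compounds differs in this one place alone, so no measured step shows what this change does. Compound 1, which carries hydrogen at that position but a different ring on the thiourea, gives 37.2%, a little below compound 3 and within the scatter. The step from compound 3 to compound 4 is therefore expected to be small, at most a modest drop, and likely no change beyond the scatter: a number 7 percentage points lower from compound 3 to compound 4 (within the scatter). For compound 4 the estimated value in this assay is 40%, with a range from 28% to 52%.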

Compound 4, percent growth inhibition at one concentration: 43.1%
Compound 4: the middle estimate sits 3.1 percentage points below what was measured; the range from low to high includes it.
By their numbers in this assay, from the lowest: compounds 2, 1, 4 and 3 (each within the scatter of the next, the first and the last beyond it).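

In this assay, hydrogen in place of fluoro on an aromatic carbon, two atoms from the ring nitrogen and para to a large group, gives a number 3.9 percentage points lower from compound 3 to compound 4 (within the scatter), which is the first direct reading of this position in the series and shows no change that can be separated from the scatter, so the fluoro is not shown to matter for growth inhibition at the one concentration tested. On the thiocarbonyl carbon, morpholin-4-yl in place of thiomorpholin-4-yl gives a number 5.9 percentage points higher from compound 1 to compound 4 (within the scatter), so with hydrogen on the aromatic ring these two groups cannot be told apart on this read-out. No measured property bears on either step.

The compounds shown leave open whether a chloro, methoxy or amino group on this same aromatic carbon would move the number beyond the scatter, since hydrogen and fluoro are the only two groups compared there. Compound 2 differs from the others in more than one place, so its steps cannot be read, and the separate contributions of its methyl group and its ring remain unresolved.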